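The source may report more compounds than this note shows. Statements on the series, on what has been measured and on what is new or still open speak of the compounds shown alone.

Among the compounds with values here, in a functional assay on MES-SA/Dx5 cells (Homo sapiens) for inhibition, with a stated time of 72 h (on this read-out higher numbers stand for weaker inhibition and lower numbers for stronger inhibition), compound 1 `Oc1c(CN2CCCC2)ccc2cccnc12` gives 1470 nM; 1450 nM (2 entries) and compound 2 `Oc1c(C(c2ccncc2)N2CCCC2)ccc2cccnc12` gives 3630 nM as its only single number. That is the higher of the figures shown and so the weaker inhibition, and a further entry for compound 2 carries no single number. Compound 3 `Oc1c(C(c2ccncc2)N2CCCCC2)ccc2cccnc12` differs from compound 2 by piperidin-1-yl in place of pyrrolidin-1-yl on a saturated chain carbon bound to two aromatic carbons on a saturated chain carbon bound to two aromatic carbons. Within the data shown here, no measured step shows what this exchange does. The estimated 1.1-fold lower number from compound 2 to compound 3 (0.04 log units; within the scatter) is expected to stay within the usual scatter in this assay with no direction favoured. Compound 3 is therefore expected at 3300 nM within an estimated range of 1500 nM to 7000 nM on this read-out.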

Compound 3, half-maximal inhibitory concentration: 8320 nM
Compound 3: middle estimate off by 2.5-fold (0.40 log units), on the low side, and the stated range ends below it.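

In this assay, the amine ring on the saturated chain carbon bound to two aromatic carbons proves to matter: piperidin-1-yl in place of pyrrolidin-1-yl gives a 2.3-fold higher number from compound 2 to compound 3 (0.36 log units; beyond the scatter), so the larger ring goes with weaker inhibition in this pair. The step is modest but beyond the scatter, and the repeat readings shown agree closely: the several entries of compound 1 in this assay, 1470 nM; 1450 nM (2 entries). On these data alone, whether this trend would extend to azetidin-1-yl, morpholin-4-yl or an open-chain dimethylamino group remains open. A single pair also cannot show whether the same exchange would have a similar effect on another core.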